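The source may hold more compounds than are shown below. What is called first, only, known or untested is meant among the compounds shown, and "the series" means these compounds.

Compound 1, `COC(=O)c1sc2cc(C#Cc3ccc(OC)cc3)cnc2c1N`, is recorded in a functional assay on A375-C5 cells (Homo sapiens) for inhibition, read by sulforhodamine B assay, with a stated time of 48 h (a higher number here means a weaker inhibitor of growth, a lower number a stronger inhibitor of growth), only as a limit, > 37500 nM. Compound 2, `COC(=O)c1sc2cc(C#Cc3ccc(N)cc3)cnc2c1N`, gives 4800 nM in this assay.

Going by the values given here, compound 2 therefore holds the only numerical value on hand; the other entry, that of compound 1, is a limit rather than a number (the limit of > 37500 nM in this assay, at which 1 of the 2 values shown sits). Among the compounds with values here, the single measured step, an at least 7.8-fold lower number from compound 1 to compound 2 (0.89 log units; beyond the scatter), is the whole of the guidance available.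

Compound 3 is `COC(=O)c1sc2cc(C#Cc3ccccc3F)cnc2c1N`. It differs from compound 2 by 2-fluorophenyl in place of 4-aminophenyl on a triple-bonded carbon. Within the data shown here, no measured step matches this change directly. Among the measured compounds shown here, the nearest evidence is the step of an at least 7.8-fold lower number from compound 1 to compound 2 (0.89 log units; beyond the scatter), in which an amino group on an aromatic carbon went with a stronger inhibitor than a methoxy group; compound 3 gives up that amino group altogether and carries a fluorine instead, and no measured compound carries a fluorine. A weakening of about that size, or somewhat smaller, is therefore expected, with a real chance that the result falls back to the limit. Compound 3 is estimated at 20000 nM, within 6000 nM to 60000 nM, which corresponds to an expected step of a 4.2-fold higher number from compound 2 to compound 3 (0.62 log units; beyond the scatter).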

Compound 3, concentration for 50% growth inhibition: > 150000 nM
Compound 3: no number, only a limit (the forecaster's own chance of this, stated with the estimate: 35%); middle value at least 7.5-fold (0.87 log units) away from the limit.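

Replacing 4-aminophenyl with 2-fluorophenyl on a triple-bonded carbon gives an at least 31-fold higher number from compound 2 to compound 3 (1.49 log units; beyond the scatter) in this assay, so a change at this place can remove measurable growth inhibition altogether. Compound 2, which carries the amino group, remains the only one of the three with a number, and neither compound 1 nor compound 3 goes against this, as each is recorded only as a limit. The step from compound 1 to compound 3 cannot be read, so 4-methoxyphenyl and 2-fluorophenyl cannot be ranked against each other, and the earlier finding that methoxy gives way to amino with a gain now has a second aryl group without the amino group alongside it.

Going by these compounds alone, what stays open is whether the loss follows the departure of the amino group or the arrival of the fluorine, as both happen in the one change. A hydroxyl group, an acetamide or a dimethylamino group in place of the amino group of compound 2 would bear on how much of the growth inhibition depends on that amine itself.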